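Pyridin-2-yl for Methyl at the Carbinol Carbon

This account rests on a few compounds, and the source may have more. Where it says the series, first, only, none or still open, it means among the compounds named here.

Compound 1 `CNc1cc(-c2cn[nH]c2)c2cc(C#CC(C)(O)c3nccs3)ccc2n1`: 26 nM
Compound 2 `CN1CCN(c2cc(-c3cn[nH]c3)c3cc(C#CC(C)(O)c4nccs4)ccc3n2)CC1`: 175 nM
Compound 3 `CC(C)(O)C#Cc1ccc2nccc(-c3cn[nH]c3)c2c1`: 1720 nM

In an assay for inhibition of mitogen-activated protein kinase kinase kinase 14 (Homo sapiens), read by luminescence and ADP-Glo, with a stated time of 120 min, in the presence of a further agent that is not named here (a higher number here means a weaker inhibitor, a lower number a stronger inhibitor), compound 3 gives the highest of the three numbers. Compound 2 is the nearest to it and compound 1 the furthest; both gaps lie beyond the scatter, so compound 3 is the weakest inhibitor of the three. Compound 4 `CC(O)(C#Cc1ccc2nccc(-c3cn[nH]c3)c2c1)c1ccccn1` differs from compound 3 in one place: pyridin-2-yl in place of methyl on a saturated chain carbon bound to an oxygen on a saturated carbon, a saturated chain carbon and a triple-bonded carbon. Going by the values given here, the only measured single-change step, a 6.7-fold higher number from compound 1 to compound 2 (0.83 log units; beyond the scatter), concerns a substituent on an aromatic carbon of the shared core, not the carbinol carbon, so it does not bear on this change. Among the compounds with values here, compounds 1 and 2 carry an aromatic group on that carbon but differ from compound 3 elsewhere as well, so no measured step isolates the change. The expectation therefore rests on the broad observation that those two compounds give lower numbers, and a lower number is expected for compound 4, a 4.9-fold lower number from compound 3 to compound 4 (0.69 log units; beyond the scatter), of uncertain size. The estimate for compound 4 is 350 nM, expected between 80 nM and 1500 nM.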

Compound 4, half-maximal inhibitory concentration: 591 nM
Estimate against measurement, compound 4: 1.7-fold (0.23 log units) below, within the range that was stated.
By their numbers in this assay, from the lowest: compound 1; then compound 2; then compound 4; then compound 3.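

Pyridin-2-yl in place of methyl on the carbinol carbon gives a 2.9-fold lower number from compound 3 to compound 4 (0.46 log units; beyond the scatter) in this assay and so isolates this change for the first time, with a step that is modest but beyond the scatter. Going by these compounds alone, an aromatic group on this carbon had until now been seen only in compounds that also differed elsewhere, whereas here it is the only difference, and the direction of the step is a lower number. No measurement shown here accounts for the step.

The compounds shown leave open whether the ring nitrogen contributes to the step or the ring alone suffices, a question that phenyl or pyridin-3-yl on the same carbon would address. They also leave open whether the step would keep its size with a methylamino group on the shared core.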